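An Ethyl Group Enters the Core of Compound 1

The source may hold more compounds than are shown below. What is called first, only, known or untested is meant among the compounds shown, and "the series" means these compounds.

compound 1, `CCCCCCCCCCn1cc(Cn2cnc3nc(-c4ccccc4)cc(C(F)(F)F)c3c2=O)nn1`: in a functional assay on COLO 205 cells (Homo sapiens) for cytotoxicity, read by MTT assay, with a stated time of 24 h (on this read-out higher numbers stand for weaker inhibition and lower numbers for stronger inhibition), compound 1 gives 19.3 ug/mL
compound 2, `Cc1nc2nc(-c3ccccc3)cc(C(F)(F)F)c2c(=O)n1Cc1cn(CCC(F)(F)C(F)(F)C(F)(F)C(F)(F)C(F)(F)C(F)(F)F)nn1`: compound 2 gives > 200 ug/mL, a limit of the assay
compound 3, `CCc1nc2nc(-c3ccccc3)cc(C(F)(F)F)c2c(=O)n1Cc1cn(CCC(F)(F)C(F)(F)C(F)(F)C(F)(F)C(F)(F)C(F)(F)F)nn1`: compound 3 gives > 200 ug/mL, also a limit of the assay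

Among the compounds with values here, compound 1 therefore holds the only number among the three values; the two others are the limit of > 200 ug/mL in this assay, at which 2 of the 3 values shown sit. The unmeasured compound 4, `CCCCCCCCCCn1cc(Cn2c(CC)nc3nc(-c4ccccc4)cc(C(F)(F)F)c3c2=O)nn1`, differs from compound 1 in a single place: ethyl in place of hydrogen on an aromatic carbon. Within the data shown here, the only measured step between compounds that differ in one place is a step that the two limits leave unreadable from compound 2 to compound 3, which runs from one limit to another and cannot be read. Among the measured compounds shown here, compound 2 and compound 3 each differ from compound 1 in two places, the chain as well as the group on the core, so no measured step bears directly on the change from compound 1 to compound 4. What the values show is that compound 1, with hydrogen at that carbon, has a number, while the two alkyl-bearing compounds sit at a limit, though their chains also differ. On this thin basis compound 4 is expected to show a step of a 2.3-fold higher number from compound 1 to compound 4 (0.37 log units; beyond the scatter) toward weaker inhibition in this assay, beyond the scatter but with wide uncertainty. The estimate for compound 4 is 45 ug/mL, in the range 12 ug/mL to 200 ug/mL.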

Compound 4, half-maximal inhibitory concentration: > 200 ug/mL
Compound 4 ended at the assay's limit (the forecaster's own chance of this, stated with the estimate: 35%); middle value at least 4.4-fold (0.64 log units) from the limit.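

In this assay, placing ethyl instead of hydrogen on the aromatic carbon between two ring nitrogen atoms, with the chain of compound 1 left unchanged, gives an at least 10-fold higher number from compound 1 to compound 4 (1.01 log units; beyond the scatter). Compound 4 gives > 200 ug/mL, which is a limit of the assay. The step between compound 2 and compound 3 cannot be read, and both of those compounds also differ from compound 1 in the chain, so this pair is the first to isolate the change at this carbon and show that it alone can carry the value from a number to the limit, and the step's size remains bounded by that limit: the limit of > 200 ug/mL in this assay, at which 3 of the 4 values shown sit.

The compounds shown leave open whether a methyl group or an amine at this carbon, on the chain of compound 1, would keep a number in this assay or also reach the limit. They also leave open how much weaker compound 4 is than its limit shows, and whether a longer chain on the triazole-bearing side would alter the effect of ethyl at this position.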